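A Second Methoxy Group on a Shared Core

This account rests on a few compounds, and the source may have more. Where it says the series, first, only, none or still open, it means among the compounds named here.

Measured so far:
compound 1, `COc1cccc(-c2ncc(C(=O)O)c(=O)[nH]2)c1`, 10 mg/kg
compound 2, `COc1ccc(-c2ncc(C(=O)O)c(=O)[nH]2)cc1`, > 5 mg/kg (a limit)
compound 3, `COc1ccc(-c2ncc(C(=O)O)c(=O)[nH]2)c(OC)c1`, 5 mg/kg

The read-out is a functional assay on the whole organism (strain Sprague-Dawley) for inhibition, with Rattus norvegicus as the target, with a stated time of 10 min; on this read-out higher numbers stand for an effect only at larger amounts of compound and lower numbers for an effect already at smaller amounts. Compound 1 gives 10 mg/kg. Compound 3 gives 5 mg/kg, and its value lies within the scatter of compound 1. For compound 2 the value > 5 mg/kg is a limit, not a number (the limit of > 5 mg/kg in this assay, at which 1 of the 3 values shown sits). Compound 1 and compound 2 are built from the same atoms joined differently; the difference between the two cores is not broken down here. From compound 2 to compound 3 the change is methoxy in place of hydrogen on an aromatic carbon and the step is a number no higher from compound 2 to compound 3 (the limit leaves the size open).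

Compound 4, `COc1ccc(OC)c(-c2ncc(C(=O)O)c(=O)[nH]2)c1`, is not yet measured. It arises from compound 1 by methoxy in place of hydrogen on an aromatic carbon, the same kind of change as from compound 2 to compound 3, though the place differs: here para to a methoxy group, there meta to a methoxy group. For compound 4 the step expected is a 1.4-fold lower number from compound 1 to compound 4 (0.15 log units; within the scatter), resting on the measured step of a number no higher from compound 2 to compound 3 (the limit leaves the size open), whose limit leaves the size open. Compound 4 is estimated to give 7 mg/kg, between 2.5 mg/kg and 20 mg/kg.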

Compound 4, dose for 50% inhibition: 1 mg/kg
Compound 4: middle estimate off by 7.0-fold (0.85 log units), on the high side; the measured number lies below the stated range.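

In this assay, adding the methoxy group to the core of compound 1 gives a clear step, a 10-fold lower number from compound 1 to compound 4 (1.00 log units; beyond the scatter). The same change can be set beside its earlier counterpart: the same change on two cores in this assay, a number no higher (the limit leaves the size open) from compound 2 to compound 3 and a 10-fold lower number (1.00 log units; beyond the scatter) from compound 1 to compound 4; the limit leaves it open whether they differ. Compound 2 is recorded only as a limit, not a number, so the size of its step cannot be read, and this single readable step does not show whether the gain carries from one core to another.

The compounds shown leave open whether a different group in the same place, such as an ethoxy group or an amine, would give a similar step. The two added methoxy groups also sit in different places, and these compounds do not separate the effect of place from that of the core.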